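Cyclopropyl for fluorophenyl in a second enone series

The compounds below may be only part of what the source reports. "The series", "measured", "known", "first", "only" and "open" are said of these compounds alone.

Compound 1 `O=C(/C=C\N(O)Cc1ccc(-c2ccccc2)cc1)c1ccc(F)cc1` and compound 2 `O=C(/C=C\N(O)Cc1ccc2ccccc2c1)c1ccc(F)cc1` share a hydroxylamine enone but differ in the core; that difference between the two cores is not broken down here. In a functional assay on cells (Homo sapiens) for inhibition (a lower number here means a stronger inhibitor, a higher number a weaker inhibitor), compound 1 gives 5200 nM, and compound 2 gives 7700 nM; the two numbers lie within the usual scatter of each other. Compound 3 `O=C(/C=C\N(O)Cc1ccc2ccccc2c1)C1CC1` gives 9900 nM in this assay. From compound 2 to compound 3 the change is cyclopropyl in place of 4-fluorophenyl on a carbonyl carbon, and it made a step of a 1.3-fold higher number from compound 2 to compound 3 (0.11 log units; within the scatter), which is within the scatter.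

Compound 4 `O=C(/C=C\N(O)Cc1ccc(-c2ccccc2)cc1)C1CC1` has not yet been measured in this assay. It carries the same change, (cyclopropyl in place of 4-fluorophenyl on a carbonyl carbon), on the core of compound 1; the place where the change sits is described identically in both pairs, so the change is the same. Because compound 2 and compound 3 showed a step of a 1.3-fold higher number from compound 2 to compound 3 (0.11 log units; within the scatter), a similar step is expected from compound 1 to compound 4, about a 1.3-fold higher number from compound 1 to compound 4 (0.12 log units; within the scatter), with no claim that this holds beyond these compounds. For compound 4 the estimated value in this assay is 6800 nM, with a range from 3000 nM to 15000 nM.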

Compound 4, half-maximal inhibitory concentration: > 10000 nM
Compound 4: only a limit was reported; the forecaster's own chance of this, stated with the estimate: 15%; middle value at least 1.4-fold (0.16 log units) away from the limit.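

In this assay compound 4 gives > 10000 nM, which is a limit of the assay and not a number. The same change, cyclopropyl in place of 4-fluorophenyl on a carbonyl carbon, therefore gives a step of an at least 1.9-fold higher number from compound 1 to compound 4 (0.28 log units; that floor lies within the scatter), and setting this beside the earlier step does not settle whether the change behaves alike on both cores: the same change on two cores in this assay, a 1.3-fold higher number (0.11 log units; within the scatter) from compound 2 to compound 3 and an at least 1.9-fold higher number (0.28 log units; that floor lies within the scatter) from compound 1 to compound 4; the limit leaves it open whether they differ The result shows only a floor for the step on the core of compound 1, so it neither confirms that the change carries over unaltered nor shows that the core alters its effect, and the reading rests on a value at the limit: the limit of > 10000 nM in this assay, at which 1 of the 4 values shown sits.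

The compounds shown leave open how large the step on the core of compound 1 really is. They also leave open how an amine, a carboxylic acid or a longer chain on that carbonyl carbon would read in this assay on either core.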